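Removing an acetyl group in a diterpene lactone series

The source may hold more compounds than are shown below. What is called first, only, known or untested is meant among the compounds shown, and "the series" means these compounds.

Measured compounds:
compound 1 `C=C1CC[C@@H]2[C@](C)(CO[Si](C)(C)C(C)(C)C)[C@H](O)CC[C@@]2(C)[C@@H]1C/C=C1/C(=O)OC[C@H]1OC(C)=O` — 3.41 uM
compound 2 `C=C1CC[C@@H]2[C@](C)(CO[Si](C)(C)C(C)(C)C)[C@H](O)CC[C@@]2(C)[C@@H]1C/C=C1/C(=O)OC[C@H]1O` — 15.5 uM
compound 3 `C=C1CC[C@@H]2[C@](C)(CO[Si](c3ccccc3)(c3ccccc3)C(C)(C)C)[C@H](OC(C)=O)CC[C@@]2(C)[C@@H]1C/C=C1/C(=O)OC[C@H]1OC(C)=O` — 32.8 uM

All three were tested in a functional assay on ASK cells (Rattus norvegicus) for cytotoxicity, read by sulforhodamine B assay; on this read-out higher numbers stand for an effect only at larger amounts of compound and lower numbers for an effect already at smaller amounts. Compound 1 gives the lowest number of the three. Compound 2 differs from compound 1 only by hydrogen in place of acetyl on an oxygen on a saturated carbon, and that change produced a 4.5-fold higher number from compound 1 to compound 2 (0.66 log units; beyond the scatter). Compound 3 gives the highest number; the difference between its core and the core of compound 1 is not broken down here.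

Compound 4 `C=C1CC[C@@H]2[C@](C)(CO[Si](c3ccccc3)(c3ccccc3)C(C)(C)C)[C@H](O)CC[C@@]2(C)[C@@H]1C/C=C1/C(=O)OC[C@H]1OC(C)=O` has not yet been measured. It differs from compound 3 by hydrogen in place of acetyl on an oxygen on a saturated carbon, the same change that separates compound 1 from compound 2. If that earlier step repeated in full, compound 4 would come out well above compound 3. Within the data shown here, because compound 3 already gives 32.8 uM, and because the earlier step was a 4.5-fold higher number from compound 1 to compound 2 (0.66 log units; beyond the scatter), the expectation here is a step of a 2.0-fold higher number from compound 3 to compound 4 (0.30 log units; within the scatter), kept smaller than the earlier one since the surrounding core is different and only one example of the change exists. The estimated value for compound 4 in this assay is 65 uM, with a range from 20 uM to 200 uM.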

Compound 4, concentration for half-maximal effect: 12 uM
For compound 4 the middle estimate is 5.4-fold (0.73 log units) above the measured one; measured number outside the range, below it.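

In this assay the acetoxy to hydroxy change gives a 2.7-fold lower number from compound 3 to compound 4 (0.44 log units; beyond the scatter) and so runs opposite to the earlier step, which means that its effect did not carry over from one core to the other, not even in direction: the same change on two cores in this assay, a 4.5-fold higher number (0.66 log units; beyond the scatter) from compound 1 to compound 2 and a 2.7-fold lower number (0.44 log units; beyond the scatter) from compound 3 to compound 4, 12-fold (1.09 log units) apart, beyond the scatter of two such steps. The result shows that, in this series, the outcome of removing an acetyl cannot be assumed from a single example on another core. Among these compounds, it does not show what causes the reversal, as there are only two pairs, their cores differ, and the acetyl leaves a different oxygen in each pair.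

The compounds shown leave open how each oxygen would behave if its acetyl were removed on one and the same core. They also leave open whether a longer ester, such as a butyrate, or a simple methyl ether in place of the acetyl would follow either step.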